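Compound 4: diethylamino in place of isopropyl(methyl)amino

The compounds below may be only part of what the source reports. "The series", "measured", "known", "first", "only" and "open" are said of these compounds alone.

Compound 1 `CCCCNc1cccc(NC(=O)C(=O)OCC)c1C#N` gives 0.3 mg/kg
Compound 2 `CCOC(=O)C(=O)Nc1cccc(N(C)CC)c1C#N` gives 0.3 mg/kg
Compound 3 `CCOC(=O)C(=O)Nc1cccc(N(C)C(C)C)c1C#N` gives 0.3 mg/kg

In a functional assay on the whole organism with Rattus norvegicus as the target (on this read-out higher numbers stand for an effect only at larger amounts of compound and lower numbers for an effect already at smaller amounts), compounds 1 and 2 sit level with compound 3, which gives 0.3 mg/kg on this scale. Compound 4 `CCOC(=O)C(=O)Nc1cccc(N(CC)CC)c1C#N` is still unmeasured and differs from compound 3 only in one group: diethylamino in place of isopropyl(methyl)amino on an aromatic carbon. In this assay the closest measured swap, ethyl(methyl)amino to isopropyl(methyl)amino, gave no change at the digits printed from compound 2 to compound 3 (within the scatter) and replacing butylamino gave no change at the digits printed from compound 1 to compound 2 (within the scatter) as well as no change at the digits printed from compound 1 to compound 3 (within the scatter) so all three steps stayed within the scatter. A step beyond the scatter is therefore not expected, and the estimated outcome is no change at the digits printed from compound 3 to compound 4 (within the scatter) for this swap. Compound 4 is expected at 0.3 mg/kg within a range from 0.15 mg/kg to 0.6 mg/kg for this read-out.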

Compound 4, dose for half-maximal effect: 0.7 mg/kg
For compound 4 the middle estimate is 2.3-fold (0.37 log units) below the measured one; the measured number lies above the stated range.
By their numbers in this assay, from the lowest: compounds 1, 2 and 3 (each within the scatter of the next); then compound 4.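

In this assay, swapping among the amino groups at this aromatic carbon had left the number unchanged until diethylamino, which gives a 2.3-fold higher number from compound 3 to compound 4 (0.37 log units; beyond the scatter) even though the two groups share the same atoms, joined differently. The other comparisons agree, with a 2.3-fold higher number from compound 2 to compound 4 (0.37 log units; beyond the scatter) and a 2.3-fold higher number from compound 1 to compound 4 (0.37 log units; beyond the scatter) as well, so all three modest steps show that diethylamino needs a larger dose. Nothing here accounts for this shift. Still open, from the compounds shown here alone, is whether dimethylamino or a ring amine such as pyrrolidine would stay level with compounds 1, 2 and 3 or move like compound 4.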